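Removing the phenyl from the indole of a carbamate FAAH inhibitor

This account rests on a few compounds, and the source may have more. Where it says the series, first, only, none or still open, it means among the compounds named here.

Measured so far:
Compound 1, `O=C(NCCCCCCn1c(-c2ccccc2)cc2ccccc21)Oc1ccccc1`: 520 nM
Compound 2, `O=C(NCCCCCCn1ccc2ccccc21)Oc1cccnc1`: 5.2 nM
Compound 3, `O=C(NCCCCCCn1cc(-c2ccccc2)c2ccccc21)Oc1ccccc1`: 4900 nM

Of the compounds shown here, three have been measured in an assay on microsomes from brain (strain Sprague-Dawley) for inhibition of Fatty-acid amide hydrolase 1 (Rattus norvegicus), read by fluorescence and HPLC, with stated times of 10 min and 60 min; a higher number here means a weaker inhibitor, a lower number a stronger inhibitor. Compound 2 carries an unsubstituted indole and a pyridyl carbamate, and in this assay compound 2 gives 5.2 nM. Compound 1 has a phenyl carbamate and a phenyl on the indole, and in this assay compound 1 gives 520 nM. Compound 3, with the phenyl on a different carbon of the indole, gives 4900 nM in this assay; this is the highest number of the three, and its distance from compound 1 and from compound 2 lies beyond the scatter in both cases.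

Compound 4 is `O=C(NCCCCCCn1ccc2ccccc21)Oc1ccccc1`. It differs from compound 3 in one place: hydrogen in place of phenyl on an aromatic carbon. For the measured compounds named here, no step between two measured compounds corresponds exactly to this change. Yet compound 2, the only measured compound without a phenyl on the indole, gives the lowest number, while compound 3 gives the highest, so a large downward step is expected. Compound 4 is therefore estimated to give 50 nM in this assay, with a range from 8 nM to 300 nM, a step of a 98-fold lower number from compound 3 to compound 4 (1.99 log units; beyond the scatter) that is expected to lie well beyond the scatter.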

Compound 4, half-maximal inhibitory concentration: 250 nM
The estimate for compound 4 lay 5.0-fold (0.70 log units) below the measured number; the measured number falls inside the stated range.
By their numbers in this assay, from the lowest: compound 2; then compound 4; then compound 1; then compound 3.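

In this assay, hydrogen in place of phenyl on the aromatic carbon two ring bonds from the ring nitrogen gives a 20-fold lower number from compound 3 to compound 4 (1.29 log units; beyond the scatter), a large step that shows directly how much higher the number is with phenyl at this position. The same exchange at the carbon that bears phenyl in compound 1 gives only a 2.1-fold lower number from compound 1 to compound 4 (0.32 log units; beyond the scatter), a modest step, though still beyond the scatter, so among these compounds phenyl on the five-membered aromatic ring goes with a higher number at both carbons, and the penalty is much larger at the position occupied in compound 3. The step of a 48-fold higher number from compound 2 to compound 4 (1.68 log units; beyond the scatter), for phenyl in place of pyridin-3-yl on the oxygen next to the carbonyl group, shows that the low number of compound 2 cannot be credited to the missing phenyl on the ring, since compound 4 also lacks that phenyl.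

Still open, as far as these compounds go, is whether a methyl, a methoxy or an amine on the same carbon would raise the number as phenyl does, and whether pyridin-3-yl on the oxygen would lower the number as far when phenyl remains on the ring. The compounds shown come with no measurement that explains any of these steps.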